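Swapping the aryl group on the piperazine of a proline thiazolidide

The source may hold more compounds than are shown below. What is called first, only, known or untested is meant among the compounds shown, and "the series" means these compounds.

Measured compounds:
- compound 1, `O=C([C@@H]1C[C@H](N2CCN(c3ccc(Br)cc3)CC2)CN1)N1CCSC1`: 9 nM
- compound 2, `COc1ccc(N2CCN([C@@H]3CN[C@H](C(=O)N4CCSC4)C3)CC2)cc1`: 16.9 nM

Two compounds share a core and differ only in the aromatic group on the ring nitrogen. In an assay on a cell-free system (plasma) for inhibition of Dipeptidyl peptidase 4 (Rattus norvegicus), read by fluorescence (a higher number here means a weaker inhibitor, a lower number a stronger inhibitor), compound 1 gives 9 nM, and compound 2 gives 16.9 nM. Compound 2 has the higher of the two numbers, but the step of a 1.9-fold higher number from compound 1 to compound 2 (0.27 log units; within the scatter) lies within the scatter, so the two cannot be told apart.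

Compound 3, `O=C([C@@H]1C[C@H](N2CCN(c3cccc(Cl)c3)CC2)CN1)N1CCSC1`, is not yet measured. Its change from compound 2 is 3-chlorophenyl in place of 4-methoxyphenyl on an amine nitrogen in a ring. Going by the values given here, the only measured step, a 1.9-fold higher number from compound 1 to compound 2 (0.27 log units; within the scatter), shows that exchanging one group on this aromatic ring for another left this assay essentially unchanged. The new group, however, carries its chlorine at a position not tested here, so that step is only a partial guide. The expected step from compound 2 to compound 3 in this assay is therefore a 1.3-fold lower number from compound 2 to compound 3 (0.11 log units; within the scatter), that is, no change beyond the scatter. Compound 3 is estimated at 13 nM, within a range of 4 nM to 45 nM.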

Compound 3, half-maximal inhibitory concentration: 7.2 nM
Compound 3: middle estimate off by 1.8-fold (0.26 log units), on the high side; measured number inside the range.
By their numbers in this assay, from the lowest: compounds 3, 1 and 2 (each within the scatter of the next, the first and the last beyond it).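

Placing the 3-chlorophenyl group on this ring nitrogen gives the first step at this position in this assay that lies beyond the scatter, though a modest one: a 2.3-fold lower number from compound 2 to compound 3 (0.37 log units; beyond the scatter). Set against the 4-bromophenyl group, the same change gives a 1.3-fold lower number from compound 1 to compound 3 (0.10 log units; within the scatter), so these two halogen-bearing aryl groups cannot be told apart even though they differ in both the halogen and its place on the ring. Nothing given here accounts for the step away from the 4-methoxyphenyl group.

Going by these compounds, whether the place of the chlorine counts on its own stays open, and a 4-chlorophenyl group on the same core would speak to that. On these data alone, it is also open how a plain phenyl group, or an aromatic ring carrying an amine or a carboxylic acid, would read in this assay.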